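Bromo in place of fluoro on the shared core

This account rests on a few compounds, and the source may have more. Where it says the series, first, only, none or still open, it means among the compounds named here.

Values in an in vitro ADME assay on microsomes from liver (Homo sapiens) for pharmacokinetics, read by LC-MS; on this read-out lower numbers stand for slow clearance and higher numbers for fast clearance:
compound 1 `Cc1cccc2c1nc(C)n2-c1ccc(C(=O)NC2CC2)s1`: 10 mL/min/kg
compound 2 `Cc1ccc2c(c1)nc(C)n2-c1ccc(C(=O)NC2CC2)s1`: 8 mL/min/kg
compound 3 `Cc1nc2c(F)cccc2n1-c1ccc(C(=O)NC2CC2)s1`: < 4 mL/min/kg (a limit, not a number)

Compound 3 gives only a limit and stands at the limit of < 4 mL/min/kg in this assay, at which 1 of the 3 values shown sits. Compound 4 `Cc1nc2c(Br)cccc2n1-c1ccc(C(=O)NC2CC2)s1` has bromo in place of fluoro on an aromatic carbon. Among the compounds with values here, the one measured step at this place is an at least 2.5-fold lower number from compound 1 to compound 3 (0.39 log units; beyond the scatter), with fluoro in place of methyl on an aromatic carbon. This step is beyond the scatter. Losing the fluoro again should therefore undo part or all of that drop, and a rise of similar size is expected in this assay, back towards compound 1 at 10 mL/min/kg. The expected change is an at least 1.7-fold higher number from compound 3 to compound 4 (0.24 log units; that floor lies within the scatter). For compound 4 the estimate is 7 mL/min/kg, with an expected range of 4 mL/min/kg to 14 mL/min/kg.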

Compound 4, clearance: 5 mL/min/kg
Compound 4: the middle estimate sits 1.4-fold (0.15 log units) above what was measured, within the range that was stated.
By their numbers in this assay, from the lowest: compounds 4, 2 and 1 (each within the scatter of the next). At a limit, below all of these: compound 3.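

In this assay, bromo in place of methyl on this aromatic carbon gives a 2.0-fold lower number from compound 1 to compound 4 (0.30 log units; within the scatter), so bromo and methyl are not separated at this position. Bromo in place of fluoro gives an at least 1.2-fold higher number from compound 3 to compound 4 (0.09 log units; that floor lies within the scatter), so bromo is not separated from fluoro either, and the position does not yet show a clear order among the three groups. That step rests on a reading for compound 3 that is a limit and not a number: the limit of < 4 mL/min/kg in this assay, at which 1 of the 4 values shown sits.

On these data alone, how far compound 3 really lies under that limit stays open. So does the reading with chloro, methoxy or an amine on this aromatic carbon.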